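Series notes: benzyl variation on a bis(trifluoromethyl)benzenesulfonamide chain

This account rests on a few compounds, and the source may have more. Where it says the series, first, only, none or still open, it means among the compounds named here.

The compounds share the core of compound 2 `O=S(=O)(NCCCNCc1ccc(Cl)c(Cl)c1)c1cc(C(F)(F)F)cc(C(F)(F)F)c1`, which in a functional assay on PANC-1 cells (Homo sapiens) for inhibition, read by MTT assay, with a stated time of 72 h (on this read-out lower numbers stand for stronger inhibition of growth and higher numbers for weaker inhibition of growth), gives 5600 nM. On the numbers shown, compound 2 stands second highest of three; its nearest neighbour is compound 3 `O=S(=O)(NCCCNCc1ccc(C(F)(F)F)cc1)c1cc(C(F)(F)F)cc(C(F)(F)F)c1`, which in this assay gives 3200 nM, and the step of a 1.8-fold lower number from compound 2 to compound 3 (0.24 log units; within the scatter) is within the scatter. Furthest away is compound 1 `O=S(=O)(NCCNCc1cccc2ccccc12)c1cc(C(F)(F)F)cc(C(F)(F)F)c1`, which in this assay gives 24000 nM; compound 1 differs from compound 2 in more than one place, so its value only shows that it lies beyond the scatter above compound 2.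

Compound 4 `O=S(=O)(NCCCNCc1ccccc1)c1cc(C(F)(F)F)cc(C(F)(F)F)c1` differs from compound 2 by phenyl in place of 3,4-dichlorophenyl on a saturated chain carbon bound to an amine nitrogen. Among the measured compounds shown here, the only measured step at this position, from compound 2 to compound 3, exchanges one substituted phenyl for another and stays within the scatter; no measured pair removes both ring substituents, so the effect of a bare phenyl is not covered. A moderately higher number is expected for compound 4, as a 1.8-fold higher number from compound 2 to compound 4 (0.25 log units; within the scatter), with a range that keeps a within-scatter outcome open. Compound 4 is therefore estimated at 10000 nM in this assay, between 3500 nM and 30000 nM.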

Compound 4, concentration for 50% growth inhibition: 16000 nM
The estimate for compound 4 lay 1.6-fold (0.20 log units) below the measured number; the measured number falls inside the stated range.
By their numbers in this assay, from the lowest: compounds 3 and 2 (each within the scatter of the next); then compounds 4 and 1 (each within the scatter of the next).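

In this assay, among the compounds shown here, stripping the ring to a bare phenyl moves the number beyond the scatter for the first time among single changes at this position, with a 2.9-fold higher number from compound 2 to compound 4 (0.46 log units; beyond the scatter) for phenyl in place of 3,4-dichlorophenyl. Hydrogen in place of trifluoromethyl on an aromatic carbon gives a 5.0-fold higher number from compound 3 to compound 4 (0.70 log units; beyond the scatter) and points the same way, whereas a 1.8-fold lower number from compound 2 to compound 3 (0.24 log units; within the scatter) shows no separation between the two substituted compounds. Across these three compounds, then, the presence of ring substituents counts for more than the choice between the two substituent patterns, and nothing available bears on why.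

Still open, on these data alone, is whether a single chlorine, a nitrile or a carboxylic acid on an aromatic carbon would keep the number near those of compound 2 and compound 3 or fall back towards that of compound 4. The effect of chain length also cannot be read, as compound 1 differs from the others in more than one place, so a longer chain carrying the 3,4-dichlorobenzyl group would be needed to separate the chain from the ring.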